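Three measured compounds and one still to be measured

A few compounds are considered here, and "the series" means these few. Any claim that something is new, unique, unknown or untested is made for them only; others in the source may bear on it.

Compound 1 `CSc1ccc(C(=O)/C=C/c2ccc([N+](=O)[O-])o2)cc1`: 40700 nM
Compound 2 `CCCCc1ccc(C(=O)/C=C/c2ccc([N+](=O)[O-])o2)cc1`: 75700 nM
Compound 3 `CCCCc1ccc(C(=O)/C=C/c2ccc([N+](=O)[O-])s2)cc1`: 81300 nM

These values come from an ADME assay on Vero cells (Chlorocebus sabaeus) for cytotoxicity, read by resazurin assay, with a stated time of 72 h; a higher number here means that more compound is tolerated, a lower number that less compound is tolerated. Compound 1 and compound 2 share a core and differ in one place, (methylsulfanyl in place of butyl on an aromatic carbon). That step, a 1.9-fold lower number from compound 2 to compound 1 (0.27 log units; within the scatter), is small. Compound 3 carries a different core; the difference between the core of compound 2 and the core of compound 3 is not broken down here, but in this assay compound 2 and compound 3 give values that lie close together. Compound 4 `CSc1ccc(C(=O)/C=C/c2ccc([N+](=O)[O-])s2)cc1` has not yet been measured. It differs from compound 3 by methylsulfanyl in place of butyl on an aromatic carbon, at the same place as before, so it is the same change. Because the earlier step of a 1.9-fold lower number from compound 2 to compound 1 (0.27 log units; within the scatter) stayed within the usual scatter, compound 4 is expected to show a step of similar size, a 1.9-fold lower number from compound 3 to compound 4 (0.28 log units; within the scatter). In this assay compound 4 is estimated at 43000 nM, likely between 20000 nM and 90000 nM.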

Compound 4, half-maximal cytotoxic concentration: > 100000 nM
Compound 4: a limit, no number; the forecaster's own chance of this, stated with the estimate: 5%; middle value at least 2.3-fold (0.36 log units) from the limit.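

In this assay compound 4 gives > 100000 nM, which is a limit of the assay and not a number. Putting methylsulfanyl in place of butyl on the core of compound 3 can therefore be read only as a floor, an at least 1.2-fold higher number from compound 3 to compound 4 (0.08 log units; that floor lies within the scatter), and this floor can be set beside the step seen on the other core: the same change on two cores in this assay, a 1.9-fold lower number (0.27 log units; within the scatter) from compound 2 to compound 1 and an at least 1.2-fold higher number (0.08 log units; that floor lies within the scatter) from compound 3 to compound 4; the limit leaves it open whether they differ. As far as these compounds go, the same change has now been tried on two cores, but the true size of the second step stays unknown, so these compounds show neither that the change carries over from one core to the other nor that it fails to.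

The compounds shown leave open how an amine, a carboxylic acid or a longer chain in that same place would read in this assay on either core.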